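The source may hold more compounds than are shown below. What is called first, only, known or untested is meant among the compounds shown, and "the series" means these compounds.

Working notes on the series. The core of compound 1 `Nc1oncc1C1CCCC1` carries a cyclopentyl ring; in an assay on isolated protein for inhibition of Tryptophan 2,3-dioxygenase (Homo sapiens), read by fluorescence and mass spectrometry, with stated times of 5 min and 15 min (a higher number here means a weaker inhibitor, a lower number a stronger inhibitor), compound 1 gives 640 nM. Compound 2 `Nc1oncc1-n1cccn1` carries instead a five-membered aromatic ring with two nitrogens, and in this assay compound 2 gives 290 nM, the lowest number of the three measured, with compound 1 as its nearest neighbour. Compound 3 `Cc1ccn(-c2cnoc2N)n1` adds a methyl to that ring, and in this assay compound 3 gives 1600 nM; the step of a 5.5-fold higher number from compound 2 to compound 3 (0.74 log units; beyond the scatter) shows that a methyl on this ring is not neutral at the position it occupies there.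

Compound 4 `Cc1cnn(-c2cnoc2N)c1` is not yet measured. It differs from compound 2 by methyl in place of hydrogen on an aromatic carbon. Going by the values given here, the only measured step that bears on it is the methyl step from compound 2 to compound 3, which is the same kind of change at a different carbon of the same ring. That step went clearly in the direction of a higher number, so for compound 4 a rise in this assay beyond the scatter is expected, though the different position leaves its size open; a step of a 2.6-fold higher number from compound 2 to compound 4 (0.41 log units; beyond the scatter) is estimated. Compound 4 is therefore expected to give about 750 nM in this assay, within a range from 250 nM to 2200 nM.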

Compound 4, half-maximal inhibitory concentration: 1600 nM
Compound 4: middle estimate off by 2.1-fold (0.33 log units), on the low side; measured number inside the range.
By their numbers in this assay, from the lowest: compound 2; then compound 1; then compounds 3 and 4 (each within the scatter of the next).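

In this assay the methyl on the aromatic carbon two ring bonds from the ring nitrogen and two ring bonds from the ring atom that bears a group of 6 heavy atoms is not neutral either, with a 5.5-fold higher number from compound 2 to compound 4 (0.74 log units; beyond the scatter). Compound 3 gives 1600 nM and compound 4 gives 1600 nM, so these two values lie within the scatter of each other and the data show no preference between the two methyl placements, while the ring without a methyl in compound 2 keeps the lower number against both. Nothing on hand explains the rise, and the finding stands as a description of the numbers only.

As far as these compounds go, whether a fluorine, a hydroxyl or an amine in place of hydrogen on this same carbon would give a number near that of compound 2 or near that of compound 4 remains open. Also open, from the compounds shown here alone, is whether a longer chain such as ethyl at this carbon would raise the number further than methyl does or leave it within the scatter of compound 4.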